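This account rests on a few compounds, and the source may have more. Where it says the series, first, only, none or still open, it means among the compounds named here.

Compound 1 `COc1ccc(-c2nc(CN(C)C)sc2-c2ccc(OC)cc2)cc1`: 8.4 uM
Compound 2 `CCOC(=O)CC(c1nc(-c2ccc(OC)cc2)c(-c2ccc(OC)cc2)s1)N1CCN(C)CC1`: 2.6 uM

In a functional assay (aorta) with Rattus norvegicus as the target (on this read-out lower numbers stand for an effect already at smaller amounts and higher numbers for an effect only at larger amounts of compound), compound 1 gives 8.4 uM, the higher of the two measured numbers; compound 2 gives the lower one, beyond the scatter. Compound 3 `COc1ccc(-c2nc(C3=CCN(C)CC3)sc2-c2ccc(OC)cc2)cc1` differs from compound 1 at a single place: a group of 7 heavy atoms (6 carbon, 1 nitrogen; one six-membered non-aromatic ring with 1 hetero atom) in place of a group of 4 heavy atoms (3 carbon, 1 nitrogen; no ring), on an aromatic carbon. Going by the values given here, no measured pair shows such a change, so the size of its step is unknown. Since both the leaving and the entering group carry one basic nitrogen, the expected step of a 1.4-fold lower number from compound 1 to compound 3 (0.15 log units; within the scatter) is small, probably within the scatter. Compound 3 is accordingly estimated at 6 uM, with a range from 2 uM to 20 uM.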

Compound 3, concentration for half-maximal effect: 5.9 uM
Compound 3: middle estimate off by 1.0-fold (0.01 log units), on the high side; measured number inside the range.
By their numbers in this assay, from the lowest: compound 2; then compounds 3 and 1 (each within the scatter of the next).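

On the aromatic carbon next to the ring nitrogen and next to the ring sulfur, the (dimethylamino)methyl group gives way to a six-membered non-aromatic ring with 1 hetero atom, and this assay shows a 1.4-fold lower number from compound 1 to compound 3 (0.15 log units; within the scatter) for this exchange. The larger group with its ring and double bond therefore leaves the read-out indistinguishable at this position. Nothing measured here offers a reason for this.

As far as these compounds go, it remains open whether a carboxylic acid or a longer chain without nitrogen would be accepted on this carbon. The compounds also leave open what the double bond in the entering ring contributes.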